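The source may hold more compounds than are shown below. What is called first, only, known or untested is meant among the compounds shown, and "the series" means these compounds.

Measured so far:
Compound 1 `COc1ccccc1C(=O)NC(=O)Nc1ccc(-c2ccccc2)c(C(F)(F)F)c1`: in a physicochemical assay for solubility (a higher number here means a more soluble compound, a lower number a less soluble compound), compound 1 gives < 1 ug/mL, which is a limit of the assay and not a number.
Compound 2 `COc1ccccc1C(=O)NC(=O)Nc1ccc(OCC(F)(F)F)c(C(F)(F)F)c1`: in this assay compound 2 gives < 1 ug/mL, again a limit of the assay.
Compound 3 `COc1ccccc1C(=O)NC(=O)Nc1ccc(-c2ccccn2)c(C(F)(F)F)c1`: in this assay compound 3 gives 28 ug/mL.

For the measured compounds named here, compound 3 thus holds the only actual number in the set; the other two values sit at the limit of < 1 ug/mL in this assay, at which 2 of the 3 values shown sit. The step from compound 1 to compound 3 is an at least 28-fold higher number from compound 1 to compound 3 (1.44 log units; beyond the scatter), and the step from compound 2 to compound 3 is an at least 28-fold higher number from compound 2 to compound 3 (1.44 log units; beyond the scatter). Between compound 1 and compound 2 the step is a step that the two limits leave unreadable from compound 1 to compound 2.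

Compound 4 `COc1ccccc1C(=O)NC(=O)Nc1ccc(C(C)C)c(C(F)(F)F)c1` differs from compound 3 by isopropyl in place of pyridin-2-yl on an aromatic carbon. Going by the values given here, both measured steps that bear on this position run toward compound 3 and are large, and the one group that gave the readable number is the one that leaves here. The step from compound 3 to compound 4 is therefore expected to be a 19-fold lower number from compound 3 to compound 4 (1.27 log units; beyond the scatter), a reversal of those gains. For compound 4 the estimate in this assay is 1.5 ug/mL, within 0.3 ug/mL to 6 ug/mL, with a fair chance that only a limit is returned.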

Compound 4, solubility: < 1 ug/mL
Compound 4 ended at the assay's limit (the forecaster's own chance of this, stated with the estimate: 55%); middle value at least 1.5-fold (0.17 log units) away from the limit.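

On this aromatic carbon, ortho to a trifluoromethyl group, isopropyl in place of pyridin-2-yl gives an at least 28-fold lower number from compound 3 to compound 4 (1.44 log units; beyond the scatter) in this assay. The smaller group without a ring thus joins phenyl and 2,2,2-trifluoroethoxy, leaving pyridin-2-yl as the only one of the four groups with a readable number, and no compound shown goes against this. The steps among compound 1, compound 2 and compound 4 cannot be read, and the set stays bunched at one limit: the limit of < 1 ug/mL in this assay, at which 3 of the 4 values shown sit.

Open, going by these compounds, is whether pyridin-3-yl, pyridin-4-yl or a morpholine on this carbon would also give a readable number. Also open, on these data alone, is how far compound 1, compound 2 and compound 4 lie apart under the limit.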